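The source may report more compounds than this note shows. Statements on the series, on what has been measured and on what is new or still open speak of the compounds shown alone.

Measured in an in vitro functional assay on CHO-CREluc cells for antagonist activity at growth hormone secretagogue receptor type 1 (Homo sapiens), read by a luciferase reporter, with a stated time of 4 h; a lower number here means a stronger inhibitor, a higher number a weaker inhibitor:
compound 1 `CN1CCN(CC(=O)N[C@]2(c3ccc(Cl)cc3)C(=O)Nc3cc(Cl)c(Cl)cc32)CC1` — 47 nM
compound 2 `CN1CCN(CC(=O)NC2(c3ccc(Cl)cc3)C(=O)Nc3cc(Cl)cc(Cl)c32)CC1` — 72 nM

Compound 1 has the lowest of the two numbers in this assay; compound 2 sits within the scatter of it, so no order between the two is claimed. Compound 3 `CN1CCN(CC(=O)NC2(c3ccc(Cl)cc3)C(=O)Nc3cc(Cl)c(Cl)cc32)CC1` is not yet measured. Its difference from compound 1 is as follows: the two compounds have the same atoms and bonds; at least one stereo element is drawn with a configuration in one of them and without one in the other: 1 of 1 stereo elements differ; a stereocentre at a saturated ring carbon is drawn S in compound 1 and without a configuration in compound 3. Within the data shown here, no step between measured compounds is recorded, so nothing in the data calibrates this change. A small step toward a higher number is expected, a 1.7-fold higher number from compound 1 to compound 3 (0.23 log units; within the scatter), or none beyond the scatter. Compound 3 is estimated at 80 nM, range 40 nM to 200 nM.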

Compound 3, half-maximal inhibitory concentration: > 10000 nM
Compound 3 was reported as a limit; the forecaster's own chance of this, stated with the estimate: 3%; middle value at least 120-fold (2.09 log units) from the limit.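

In this assay compound 3 gives > 10000 nM, which is a limit of the assay and not a number. The stereocentre at the saturated ring carbon alone accounts for an at least 210-fold higher number from compound 1 to compound 3 (2.32 log units; beyond the scatter), a sensitivity that the earlier compounds could not reveal. This position therefore matters far more than any earlier value suggested, since nothing else separates the pair: the fact that one of compounds 1 and 3 is drawn with a defined configuration and the other without, at the place where they differ

On these data alone, whether compound 3 is a mixture or holds the opposite configuration stays open, as its drawing does not say. Also open, as far as these compounds go, is whether a nitrile or a methoxy group in place of a chlorine would keep the activity of compound 1.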